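The compounds below may be only part of what the source reports. "The series", "measured", "known", "first", "only" and "open" are said of these compounds alone.

Values in a functional assay on SGC-7901 cells (Homo sapiens) for inhibition, read by MTT assay, with a stated time of 24 h; a lower number here means a stronger inhibitor, a higher number a weaker inhibitor:

- Compound 1 `CC1(C)[C@H]2CC[C@]1(C)N(Cc1cn(-c3ccccc3F)nn1)C(=O)C2` gives 300 nM
- Compound 2 `CC1(C)[C@H]2CC[C@]1(C)N(Cc1cn(-c3ccccc3Cl)nn1)C(=O)C2` gives 220 nM
- Compound 3 `CC1(C)[C@H]2CC[C@]1(C)N(Cc1cn(-c3cccc(Br)c3)nn1)C(=O)C2` gives 120 nM

The three compounds share one core and differ only in the substituted phenyl group on the aromatic nitrogen. Compound 3 is set apart from one measured neighbour by a 2.5-fold lower number from compound 1 to compound 3 (0.40 log units; beyond the scatter), but not from the other, with a 1.8-fold lower number from compound 2 to compound 3 (0.26 log units; within the scatter). The remaining measured step, a 1.4-fold lower number from compound 1 to compound 2 (0.13 log units; within the scatter), exchanges one halogen for another on the phenyl group.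

The unmeasured compound 4 `COc1ccc(-n2cc(CN3C(=O)C[C@@H]4CC[C@@]3(C)C4(C)C)nn2)cc1` carries 4-methoxyphenyl in place of 3-bromophenyl on an aromatic nitrogen. The two steps ending at compound 3 bear most directly on this change, as both also replace the whole substituted phenyl group. They were small, the larger being the modest 2.5-fold lower number from compound 1 to compound 3 (0.40 log units; beyond the scatter). Going by the values given here, no measured step brings in a 4-methoxyphenyl group, so the data fix the direction poorly. In this assay a step within the scatter is therefore expected, with only a tentative lean towards a higher number. The estimated step is a 1.7-fold higher number from compound 3 to compound 4 (0.22 log units; within the scatter). For compound 4 the expected value is 200 nM, with an estimated range from 90 nM to 450 nM.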

Compound 4, half-maximal inhibitory concentration: 480 nM
Compound 4: the middle estimate sits 2.4-fold (0.38 log units) below what was measured; the measured number lies above the stated range.
By their numbers in this assay, from the lowest: compounds 3, 2, 1 and 4 (each within the scatter of the next, the first and the last beyond it).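

In this assay, the earlier compounds had shown only small steps among halogen-bearing phenyl groups, and the 4-methoxyphenyl group now shows that a change at this position on the aromatic nitrogen can also push the number up beyond the scatter, with a 4.0-fold higher number from compound 3 to compound 4 (0.60 log units; beyond the scatter) and a 2.2-fold higher number from compound 2 to compound 4 (0.34 log units; beyond the scatter). The first of these is the largest step in the set, yet the change does not separate the new compound from every halogen-bearing neighbour, as a 1.6-fold higher number from compound 1 to compound 4 (0.20 log units; within the scatter) shows, so the 4-methoxyphenyl group cannot be placed apart from the 2-fluorophenyl group. Nothing given here accounts for these differences.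

The compounds shown leave open whether the rise belongs to the methoxy group itself or to where it sits on the phenyl ring, as each step changes the group and its place together, and a 3-methoxyphenyl or 4-bromophenyl group would be needed to part the two. Also open is how a phenyl group carrying an amine or a carboxylic acid would read in this assay, since every substituent shown is a halogen or a methoxy group.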